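Compound 3 to compound 4: neopentyl to cyclopentyl

The compounds below may be only part of what the source reports. "The series", "measured", "known", "first", "only" and "open" are said of these compounds alone.

Compound 1 `CC(C)CNc1c(C(N)=O)cnn2cc(-c3ccccc3)cc12`, compound 2 `CC(C)CCNc1c(C(N)=O)cnn2cc(-c3ccccc3)cc12` and compound 3 `CC(C)(C)CNc1c(C(N)=O)cnn2cc(-c3ccccc3)cc12` share one core. In an ADME assay on microsomes (Mus musculus) for metabolic stability, with a stated time of 10 min (a lower number here means that less of the compound is left, a higher number that more of the compound is left), compound 1 gives < 50%, which is a limit. In this assay compound 2 gives < 50%, also a limit. In this assay compound 3 gives < 50%, again a limit and not a number. Compound 3 therefore shares its standing with the other two: the limit of < 50% in this assay, at which 3 of the 3 values shown sit.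

Compound 4 `NC(=O)c1cnn2cc(-c3ccccc3)cc2c1NC1CCCC1` has cyclopentyl in place of neopentyl on a nitrogen on an aromatic ring.

Among the compounds with values here, three measured steps bear on this change: a step that the two limits leave unreadable from compound 1 to compound 2, a step that the two limits leave unreadable from compound 1 to compound 3 and a step that the two limits leave unreadable from compound 2 to compound 3. None of them has a readable size or direction, so the data support no expected shift in either direction. The expected step is a step that the limit leaves unreadable from compound 3 to compound 4, with nothing expected beyond the scatter. For compound 4 the estimated value in this assay is 30%, with an expected range from 10% to 55%.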

Compound 4, percent of the compound remaining: < 50%
Compound 4 ended at the assay's limit (the forecaster's own chance of this, stated with the estimate: 70%); the middle value does not contradict the limit.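

In this assay compound 4 gives < 50%, a limit and not a number. Within the data shown here, no step from compound 1, compound 2 or compound 3 to compound 4 can be read. Left open is how far these four compounds actually lie apart, with all of them at one limit: the limit of < 50% in this assay, at which 4 of the 4 values shown sit.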